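Methoxy replacing the dimethylmorpholine chain: working notes

This account rests on a few compounds, and the source may have more. Where it says the series, first, only, none or still open, it means among the compounds named here.

Measured so far in a physicochemical assay for solubility, in phosphate buffer, with a stated time of 18 h, at pH 7.4; a lower number here means a less soluble compound, a higher number a more soluble compound:
- compound 1 `COc1cc2ncnc(-n3nc(-c4ccccn4)nc3N)c2cc1OCc1ccccc1`: 58000 nM
- compound 2 `COc1cc2ncnc(-n3nc(-c4ccccn4)nc3N)c2cc1OCCCN1CC(C)OC(C)C1`: 8000 nM

Compound 2 stands lower of the two, at 8000 nM on this short series. Compound 3 `COCCOc1cc2c(-n3nc(-c4ccccn4)nc3N)ncnc2cc1OC` is the next to be read. It carries methoxy in place of (2,6-dimethylmorpholin-4-yl)methyl on a saturated chain carbon, two bonds along the chain from an oxygen on an aromatic ring. The side chain thus reads 2-methoxyethoxy instead of 3-(2,6-dimethylmorpholin-4-yl)propoxy.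

Among the compounds with values here, only one measured step bears on this change: a 7.3-fold lower number from compound 1 to compound 2 (0.86 log units; beyond the scatter). That step is modest, and it ends in the group that compound 3 gives up. Within the data shown here, compound 3 does not regain the group of compound 1, and no compound with a methoxy-ended chain has been measured, so the guide is loose. The upper reference remains compound 1 at 58000 nM, and only a partial return toward it is expected. In this assay a modest step toward a higher number is expected, a 2.5-fold higher number from compound 2 to compound 3 (0.40 log units; beyond the scatter), with wide uncertainty. For compound 3 the estimated value is 20000 nM, within an expected range of 6000 nM to 70000 nM.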

Compound 3, solubility: 8000 nM
Compound 3: the middle estimate sits 2.5-fold (0.40 log units) above what was measured; measured number inside the range.
By their numbers in this assay, from the lowest: compounds 2 and 3 (each within the scatter of the next); then compound 1.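

In this assay, methoxy in place of (2,6-dimethylmorpholin-4-yl)methyl on a saturated chain carbon, two bonds along the chain from an oxygen on an aromatic ring, gives no change at the digits printed from compound 2 to compound 3 (within the scatter) and so the two chain ends cannot be told apart at this position. Methoxymethyl in place of phenyl on a saturated chain carbon bound to an oxygen on an aromatic ring gives a 7.3-fold lower number from compound 1 to compound 3 (0.86 log units; beyond the scatter) and this matches a 7.3-fold lower number from compound 1 to compound 2 (0.86 log units; beyond the scatter) at the digits printed, so compound 1 stands apart from two quite different chain ends, one with a six-membered non-aromatic ring and one with no ring. No supporting measurement on these compounds bears on the reason for this reading.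

The steps from compound 1 exchange phenyl for a whole chain end, so the effect of chain length cannot be read apart from that of the group at its end. As far as these compounds go, it also remains open whether the same reading would hold for a shorter alkoxy chain, or for a chain ending in a carboxylic acid or a simple primary amine.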